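Ethoxy to Methoxy: Expecting a Small Step

A few compounds are considered here, and "the series" means these few. Any claim that something is new, unique, unknown or untested is made for them only; others in the source may bear on it.

Of the compounds shown here, two with a shared core have been measured so far. Compound 1 `CCOc1ccc(S(=O)(=O)N2CCN(Cc3ccccc3)CC2)cc1S(=O)(=O)N1CCN(Cc2ccccc2)CC1` and compound 2 `COc1ccc(S(=O)(=O)N2CCN(c3cccc(C)c3)CC2)cc1S(=O)(=O)N1CCN(c2cccc(C)c2)CC1` differ in more than one place, so only their two values can be set side by side. In an ADME assay on L929 cells (Mus musculus) for cytotoxicity, read by CCK-8 assay, with a stated time of 48 h, tested at 100 uM (a higher number here means a weaker effect of the compound at the concentration tested, a lower number a stronger effect), compound 1 gives 22.2%, the lower of the two numbers, while compound 2 gives 66.7%, a gap beyond the usual scatter of this measurement.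

Compound 3 `COc1ccc(S(=O)(=O)N2CCN(Cc3ccccc3)CC2)cc1S(=O)(=O)N1CCN(Cc2ccccc2)CC1` has not yet been measured. It differs from compound 1 in a single place: hydrogen in place of methyl on a saturated chain carbon bound to an oxygen on an aromatic ring. Within the data shown here, no measured pair here shows what this change alone does. With so little of the structure altered, the step of a number 5.8 percentage points higher from compound 1 to compound 3 (within the scatter) is expected to be small, in either direction or none beyond the scatter. Compound 3 is therefore estimated to give 28% in this assay, with a range from 12% to 50%.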

Compound 3, a percentage reported as activity, at one concentration (the size of the read-out at that concentration, not a potency): 22.2%
Compound 3: the middle estimate sits 5.8 percentage points above what was measured; measured number inside the range.
By their numbers in this assay, from the lowest: compounds 1 and 3 (each within the scatter of the next); then compound 2.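

In this assay, among these compounds, the swap of ethoxy to methoxy, with hydrogen in place of methyl on a saturated chain carbon bound to an oxygen on an aromatic ring, brings no change at the digits printed from compound 1 to compound 3 (within the scatter) and gives the first direct reading of this one change. The earlier pair differed in more than one place, so its gap could not be tied to any single change, whereas this pair shows that, on this core, ethyl and methyl on that oxygen cannot be told apart in this measurement. Nothing measured here offers an explanation for this result.

As far as these compounds go, whether a longer chain such as propyl on the same oxygen would also leave the number unmoved remains open. So does what an amine or a carboxylic acid at this place would do.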